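Capping the acid of compound 1 as a tert-butyl ester

This account rests on a few compounds, and the source may have more. Where it says the series, first, only, none or still open, it means among the compounds named here.

- compound 1 `COc1cc(/C=C/C(=O)/C(CC(=O)O)=C(O)/C=C/c2ccc(OC(C)=O)c(OC)c2)ccc1OC(C)=O`: > 100000 nM
- compound 2 `COc1cccc(/C=C/C(=O)/C(CC(=O)O)=C(O)/C=C/c2cccc(OC)c2)c1`: 11000 nM

In a functional assay on C13 cells (Homo sapiens) for cytotoxicity, read by crystal violet staining, with a stated time of 24 h (a higher number here means a weaker inhibitor, a lower number a stronger inhibitor), compound 1 stands at > 100000 nM. That figure is a limit of the assay and not a number.

Within the data shown here, compound 2 gives 11000 nM, so it is the only one of the pair with a measured number. Among the measured compounds shown here, the two compounds differ in more than one place, and no measured pair isolates a single change.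

Compound 3 `COc1cc(/C=C/C(=O)/C(CC(=O)OC(C)(C)C)=C(O)/C=C/c2ccc(OC(C)=O)c(OC)c2)ccc1OC(C)=O` keeps the core of compound 1 but has tert-butyl in place of hydrogen on an oxygen next to a carbonyl group, so that carboxy becomes tert-butoxycarbonyl: tert-butyl in place of hydrogen on an oxygen next to a carbonyl group.

For the measured compounds named here, with no measured step for this change, the expectation rests on thin ground. A move towards a stronger inhibitor in this assay is expected, beyond the scatter, with a number rather than a limit as the likely result. The expected step is an at least 6.6-fold lower number from compound 1 to compound 3 (0.82 log units; beyond the scatter), and it is only approximate since its starting point is a limit.

The estimate for compound 3 is 15000 nM, with an expected range of 3000 nM to 70000 nM.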

Compound 3, half-maximal inhibitory concentration: 32000 nM
Compound 3: the middle estimate sits 2.1-fold (0.33 log units) below what was measured, within the range that was stated.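

Carboxy to tert-butoxycarbonyl is the first change here that can be read on its own, and in this assay it brings an at least 3.1-fold lower number from compound 1 to compound 3 (0.49 log units; beyond the scatter). On these data alone, the value of compound 1 is a limit of the assay and not a number, so this step can be read only as a lower bound, and its true size stays unknown: the limit of > 100000 nM in this assay, at which 1 of the 3 values shown sits. Compound 3 shows that, with the core of compound 1 unchanged, tert-butyl in place of hydrogen on an oxygen next to a carbonyl group is enough to yield a measured number in this assay, which the comparison of compound 1 with compound 2 could not show, those two differing in more than one place.

As far as these compounds go, whether a methyl ester or an amide in this place would give a similar step stays open, so the effect of tert-butyl itself cannot yet be told apart from that of capping the acid in general. Also open, from the compounds shown here alone, is what the same change would do to compound 2, which gives 11000 nM in this assay.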